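The source may hold more compounds than are shown below. What is called first, only, known or untested is meant among the compounds shown, and "the series" means these compounds.

Of the compounds shown here, two have so far been tested in a functional assay on Ehrlich cells (Mus musculus) for cytotoxicity, tested at 10 ug/mL; a higher number here means a stronger effect of the compound at the concentration tested, a lower number a weaker effect. Compound 1 `COc1ccc(C2C(C#N)=C(N)N(c3cc(OC)c(OC)c(OC)c3)C3=C2C(=O)CC(C)(C)C3)cc1` gives 0%, and compound 2 `COc1cc(N2C(N)=C(C#N)C(/C=C/c3ccccc3)C3=C2CC(C)(C)CC3=O)cc(OC)c1OC` gives 10%, so the two sit within the usual scatter of each other and neither shows a clear effect at the concentration tested. Among the compounds with values here, the single measured step, a number 10 percentage points higher from compound 1 to compound 2 (within the scatter), exchanges a group on a saturated ring carbon of the shared core and stays within the scatter.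

Compound 3 `COc1cc(N2C(N)=C(C#N)C(c3c(OC)ccc4ccccc34)C3=C2CC(C)(C)CC3=O)cc(OC)c1OC` has not yet been measured. It differs from compound 2 by 2-methoxynaphthalen-1-yl in place of 2-phenylethenyl on a saturated ring carbon. Within the data shown here, the only step that bears on a change at this saturated ring carbon is a number 10 percentage points higher from compound 1 to compound 2 (within the scatter), and it was within the scatter, so the step of no change at the digits printed from compound 2 to compound 3 (within the scatter) is estimated to stay within the scatter as well. Compound 3 is therefore expected to give about 10% in this assay, in a range from 0% to 25%.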

Compound 3, a percentage reported as activity, at one concentration (the size of the read-out at that concentration, not a potency): 0%
Beside the measured number, compound 3's estimate is 10 percentage points above it; low and high end bracket the measured number.
By their numbers in this assay, from the lowest: compounds 1, 3 and 2 (each within the scatter of the next).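

At this saturated ring carbon, 2-methoxynaphthalen-1-yl in place of 2-phenylethenyl adds a second aromatic ring and a hydrogen-bond acceptor, and this assay shows a number 10 percentage points lower from compound 2 to compound 3 (within the scatter) for this exchange. Measured against 4-methoxyphenyl, the same group gives no change at the digits printed from compound 1 to compound 3 (within the scatter), so all three groups tried at this carbon now lie within the scatter of one another, and none shows a clear effect at the concentration tested. No measurement is available to explain why these groups read alike.

From the compounds shown here alone, all three groups carry aromatic rings of carbon only, so it remains open what an amine, a carboxylic acid or a longer alkyl chain would do at this carbon. Going by these compounds, the 3,4,5-trimethoxyphenyl group on the ring nitrogen is common to all three compounds, so the effect of a plain phenyl there also remains open.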